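The source may hold more compounds than are shown below. What is called first, only, known or untested is meant among the compounds shown, and "the series" means these compounds.

Compound 1, `CC1(c2ccc(F)cc2)NC(=O)N(CC(O)CN2CCN(c3ccccc3)CC2)C1=O`, gives 223 nM in an assay on HEK293 cells for displacement of a labelled ligand from 5-hydroxytryptamine receptor 7 (Homo sapiens); on this read-out lower numbers stand for stronger inhibition and higher numbers for weaker inhibition; compound 2, `CC1(c2ccc(F)cc2)NC(=O)N(CC(O)CN2CCN(c3ccc(F)cc3)CC2)C1=O`, gives 837 nM.

Within the data shown here, of these two numbers compound 2 stands highest; the only measured step is a 3.8-fold higher number from compound 1 to compound 2 (0.57 log units; beyond the scatter), a modest rise beyond the scatter. Compound 3, `CC1(c2ccc(F)cc2)NC(=O)N(CC(O)CN2CCN(c3ccc(Cl)c(Cl)c3)CC2)C1=O`, differs from compound 2 by 3,4-dichlorophenyl in place of 4-fluorophenyl on an amine nitrogen in a ring. Among the measured compounds shown here, no measured pair shows two chlorines entering that ring, so the expectation rests on the one step. Compound 3 is expected to lie near or somewhat above compound 2, by a 1.8-fold higher number from compound 2 to compound 3 (0.25 log units; within the scatter) in this assay. The estimate for compound 3 is 1500 nM, between 500 nM and 4500 nM.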

Compound 3, inhibition constant: 141 nM
Compound 3: the middle estimate sits 11-fold (1.03 log units) above what was measured; the whole stated range lies above it.
By their numbers in this assay, from the lowest: compounds 3 and 1 (each within the scatter of the next); then compound 2.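

On the aromatic group carried by the ring amine nitrogen, 3,4-dichlorophenyl does not share the weaker result seen with 4-fluorophenyl: this assay shows a 5.9-fold lower number from compound 2 to compound 3 (0.77 log units; beyond the scatter) and then a 1.6-fold lower number from compound 1 to compound 3 (0.20 log units; within the scatter) so that compound 3 stays level with compound 1, which carries plain phenyl. Halogens at this position therefore do not all act alike, and the single fluoro step gave no guide to this change. Nothing available here accounts for the difference between the two halogen patterns.

The compounds shown leave open whether one chlorine alone would follow compound 3 or compound 2. They also leave open how a methoxy or trifluoromethyl group on this phenyl would compare.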